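A few compounds are considered here, and "the series" means these few. Any claim that something is new, unique, unknown or untested is made for them only; others in the source may bear on it.

Measured compounds: compound 1 `Cc1nc(N)sc1CCCNC(=N)NC(=O)CC(C)C1CCCCC1` with 7.59 nM; compound 2 `C[C@H](CC(=O)NC(=N)NCCCc1c[nH]cn1)c1ccccc1` with 75.9 nM; compound 3 `Cc1nc(N)sc1CCCNC(=N)NC(=O)C[C@@H](C)c1ccccc1` with 17 nM.

In an in vitro functional assay on Sf9 cells for agonist activity at histamine H2 receptor (Cavia porcellus), read by GTPgammaS binding (on this read-out lower numbers stand for an effect already at smaller amounts and higher numbers for an effect only at larger amounts of compound), compound 1 gives 7.59 nM, the lowest of the three numbers. Its nearest neighbour is compound 3, at a 2.2-fold higher number from compound 1 to compound 3 (0.35 log units; beyond the scatter); the furthest is compound 2, whose value of 75.9 nM lies further away, beyond the scatter. Between compound 2 and compound 3 the change at the chain end gives a 4.5-fold lower number from compound 2 to compound 3 (0.65 log units; beyond the scatter).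

The unmeasured compound 4 `Cc1nc(N)sc1CCCNC(=N)NC(=O)C[C@@H](C)C1CCCCC1` differs from compound 1 as follows: the two compounds have the same atoms and bonds; at least one stereo element is drawn with a configuration in one of them and without one in the other: 1 of 2 stereo elements differ; a stereocentre at a saturated chain carbon is drawn without a configuration in compound 1 and R in compound 4. The account therefore follows a single stereocentre being drawn without a configuration in compound 1 and as R in compound 4, with nothing entering or leaving.

Going by the values given here, no measured step bears directly on this. The two steps recorded, a 2.2-fold higher number from compound 1 to compound 3 (0.35 log units; beyond the scatter) and a 4.5-fold lower number from compound 2 to compound 3 (0.65 log units; beyond the scatter), both change a group rather than a configuration, so neither tells how the two configurations of compound 1 differ in this assay. A drawing without configuration may stand for a mixture; if so, the R form alone is expected to come out the same or somewhat lower.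

Compound 4 is thus expected at about 5 nM, with a range from 2.5 nM to 15 nM, meaning an expected step of a 1.5-fold lower number from compound 1 to compound 4 (0.18 log units; within the scatter) that may well stay within the scatter.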

Compound 4, half-maximal effective concentration: 13.2 nM
For compound 4 the middle estimate is 2.6-fold (0.42 log units) below the measured one, and the stated range covers the measured number.
By their numbers in this assay, from the lowest: compounds 1, 4 and 3 (each within the scatter of the next, the first and the last beyond it); then compound 2.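

In this assay the step of a 1.7-fold higher number from compound 1 to compound 4 (0.24 log units; within the scatter) shows that drawing this saturated chain carbon as R does not separate the two compounds beyond the scatter, and that step rests on a difference in the drawing alone: the fact that one of compounds 1 and 4 is drawn with a defined configuration and the other without, at the place where they differ. Going by these compounds alone, the new compound also allows the first comparison of cyclohexyl with phenyl at this carbon with a configuration drawn in both compounds, and that comparison gives a 1.3-fold lower number from compound 3 to compound 4 (0.11 log units; within the scatter), whereas the earlier comparison, with the configuration undrawn in compound 1, gave a 2.2-fold higher number from compound 1 to compound 3 (0.35 log units; beyond the scatter) and lay beyond the scatter. Among these compounds, then, the earlier gap between cyclohexyl and phenyl does not hold as a firm preference for either group once compound 4 takes the place of compound 1.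

As far as these compounds go, the S form of this carbon stays open, and so does the question of whether compound 1 is a mixture of the two forms. From the compounds shown here alone, how a cyclopentyl or a tert-butyl group in place of the cyclohexyl would behave in this assay also remains open.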